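This account rests on a few compounds, and the source may have more. Where it says the series, first, only, none or still open, it means among the compounds named here.

Compound 1, `C=C1CC[C@@H]2[C@](C)(COC(C)=O)[C@H](OC(C)=O)CC[C@@]2(C)[C@H]1CC(Nc1ccc(S(=O)(=O)Nc2nccc(C)n2)cc1)C1=CCOC1=O`: 43300 nM
Compound 2, `C=C1CC[C@@H]2[C@](C)(COC(C)=O)[C@H](OC(C)=O)CC[C@@]2(C)[C@H]1CC(Nc1ccc(S(=O)(=O)Nc2nccs2)cc1)C1=CCOC1=O`: 52200 nM

Of the compounds shown here, two have been tested in a functional assay on PC-3 cells (Homo sapiens) for inhibition, read by sulforhodamine B assay, with a stated time of 48 h; a higher number here means that more compound is tolerated, a lower number that less compound is tolerated. Compound 1 `C=C1CC[C@@H]2[C@](C)(COC(C)=O)[C@H](OC(C)=O)CC[C@@]2(C)[C@H]1CC(Nc1ccc(S(=O)(=O)Nc2nccc(C)n2)cc1)C1=CCOC1=O` gives 43300 nM, and compound 2 `C=C1CC[C@@H]2[C@](C)(COC(C)=O)[C@H](OC(C)=O)CC[C@@]2(C)[C@H]1CC(Nc1ccc(S(=O)(=O)Nc2nccs2)cc1)C1=CCOC1=O` gives 52200 nM. Among the measured compounds shown here, the single measured step, a 1.2-fold higher number from compound 1 to compound 2 (0.08 log units; within the scatter), lies within the scatter, so compound 2 holds the higher of the two numbers without being separable from compound 1.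

Compound 3 `C=C1CC[C@@H]2[C@](C)(COC(C)=O)[C@H](OC(C)=O)CC[C@@]2(C)[C@H]1CC(Nc1ccc(S(=O)(=O)Nc2cc(C)on2)cc1)C1=CCOC1=O` carries the change (5-methyl-1,2-oxazol-3-yl in place of 1,3-thiazol-2-yl on a sulfonamide nitrogen). For the measured compounds named here, the only measured step that bears on this kind of change is a 1.2-fold higher number from compound 1 to compound 2 (0.08 log units; within the scatter), in which one aromatic group on the sulfonamide nitrogen was exchanged for another and the number stayed essentially where it was. On that basis the expected step is a 1.1-fold lower number from compound 2 to compound 3 (0.04 log units; within the scatter), meaning no movement beyond the scatter. Compound 3 is therefore estimated at 48000 nM, with a range from 24000 nM to 96000 nM. Going by the values given here, only a single step of this kind is available. The range is deliberately kept wide.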

Compound 3, concentration lethal to 50% of the cells: 9400 nM
Compound 3: the middle estimate sits 5.1-fold (0.71 log units) above what was measured; measured number below the stated range.
By their numbers in this assay, from the lowest: compound 3; then compounds 1 and 2 (each within the scatter of the next).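

In this assay the group on the sulfonamide nitrogen now proves able to move the number: 5-methyl-1,2-oxazol-3-yl in place of 1,3-thiazol-2-yl gives a 5.6-fold lower number from compound 2 to compound 3 (0.74 log units; beyond the scatter) and the same group in place of 4-methylpyrimidin-2-yl gives a 4.6-fold lower number from compound 1 to compound 3 (0.66 log units; beyond the scatter) in the same direction. The earlier pair had shown only one exchange of aromatic groups without a separable change, whereas here 1,3-thiazol-2-yl and 5-methyl-1,2-oxazol-3-yl share a five-membered aromatic ring with 2 hetero atoms and still differ beyond the scatter, so that description alone does not decide the outcome at this nitrogen. Nothing measured here accounts for the step.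

The compounds shown leave open whether the step belongs to the 1,2-oxazole ring itself or to its methyl group, since the two enter together in compound 3; the unsubstituted 1,2-oxazol-3-yl group would separate them. They also leave open whether a longer chain than methyl on that ring, such as ethyl, would carry the number further down or bring it back.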